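Adding a second hydroxy group: what solubility may follow

A few compounds are considered here, and "the series" means these few. Any claim that something is new, unique, unknown or untested is made for them only; others in the source may bear on it.

Measured so far:
Compound 1, `O=C(/C=C/c1cc(O)ccc1O)CC(=O)/C=C/c1cccc(O)c1O`: 100000 nM
Compound 2, `O=C(/C=C/c1ccccc1O)CC(=O)/C=C/c1cc(O)ccc1O`: 4400 nM
Compound 3, `O=C(/C=C/c1cccc(O)c1)CC(=O)c1ccc(O)c(O)c1`: 25000 nM

Of the compounds shown here, three have been measured in a physicochemical assay for solubility, using the shake flask method, with a stated time of 12 h; on this read-out lower numbers stand for lower solubility and higher numbers for higher solubility. Compound 2 and compound 1 differ in one place, (hydroxy in place of hydrogen on an aromatic carbon), and that change gave a 23-fold higher number from compound 2 to compound 1 (1.36 log units; beyond the scatter). Compound 3 stands second highest of the three; the difference between its core and the core of compound 2 is not broken down here.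

Compound 4, `O=C(/C=C/c1cc(O)ccc1O)CC(=O)c1ccc(O)c(O)c1`, has not yet been measured. It differs from compound 3 by hydroxy in place of hydrogen on an aromatic carbon. Within the data shown here, this is the same kind of change as the one from compound 2 to compound 1, but not the same: in compound 1 the entering hydroxy sits ortho to a hydroxy group and meta to a large group, whereas in compound 4 it sits ortho to a large group and para to a hydroxy group.

Among the measured compounds shown here, the earlier step is the only guide, and it rests on one pair. An increase of a 2.8-fold higher number from compound 3 to compound 4 (0.45 log units; beyond the scatter) is expected for compound 4 in this assay, because in this assay the same kind of change gave a 23-fold higher number from compound 2 to compound 1 (1.36 log units; beyond the scatter). The expected value for compound 4 is 70000 nM, with an expected range from 20000 nM to 250000 nM.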

Compound 4, solubility: 47000 nM
Compound 4: the middle estimate sits 1.5-fold (0.17 log units) above what was measured; the range from low to high includes it.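

In this assay, putting hydroxy in place of hydrogen on an aromatic carbon gave a 1.9-fold higher number from compound 3 to compound 4 (0.27 log units; within the scatter), a step that lies within the usual scatter of repeated measurements, whereas the same kind of change gave a 23-fold higher number from compound 2 to compound 1 (1.36 log units; beyond the scatter), a step beyond that scatter. This shows that, across these two pairs, the size of the step did not carry over from one core to the other, so the large step alone is a poor guide to what this change will do elsewhere in the series; it does not show that the change has no effect on the core of compound 3, nor does it separate the role of the core from that of the place where the hydroxy enters, since the two pairs differ in both. Nothing available here accounts for the contrast between the two steps.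

With only two pairs, the compounds shown leave open how the same change behaves on other cores or at other places on the ring. They also leave open what an amine, a carboxylic acid or a methoxy group on the same aromatic carbon would do to this read-out.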